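The source may hold more compounds than are shown below. What is called first, only, known or untested is meant among the compounds shown, and "the series" means these compounds.

Series measured so far in a functional assay on MCF7 cells (Homo sapiens) for antiproliferative activity, read by MTT assay; a higher number here means a weaker inhibitor, a lower number a stronger inhibitor:

- compound 1 `CN1CCC(=O)/C(=C/c2ccc(OC3CCCC3)cc2)C1`: 18100 nM
- compound 2 `CC(=O)/C=C/c1ccc(OC2CCCC2)cc1`: 40900 nM
- compound 3 `O=C1CCCCC/C1=C\c1ccc(OC2CCCC2)cc1`: 64700 nM

Compound 1 has the lowest number of the three and is therefore the strongest inhibitor measured so far. Its gaps to the other two both lie beyond the usual scatter, with compound 2 nearer at 40900 nM and compound 3 further away at 64700 nM.

The next compound is compound 4 `CCN1CCC(=O)/C(=C/c2ccc(OC3CCCC3)cc2)C1`, which keeps the core of compound 1 and changes only one place: methyl in place of hydrogen on a saturated chain carbon bound to an amine nitrogen in a ring. This puts methyl in place of hydrogen on a saturated chain carbon bound to an amine nitrogen in a ring, so that, cut one bond further out, methyl becomes ethyl. Going by the values given here, no pair of measured compounds differs in only one place, so the series offers no direct precedent for this change. The estimate therefore starts from compound 1 at 18100 nM, and the change is small enough that no shift beyond the scatter is expected, in either direction. The expected result is a 1.0-fold lower number from compound 1 to compound 4 (0.00 log units; within the scatter), with no direction favoured. For compound 4 the estimated value is 18000 nM, with an expected range of 8500 nM to 36000 nM.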

Compound 4, half-maximal inhibitory concentration: 13700 nM
The estimate for compound 4 lay 1.3-fold (0.12 log units) above the measured number; the measured number falls inside the stated range.
By their numbers in this assay, from the lowest: compounds 4 and 1 (each within the scatter of the next); then compounds 2 and 3 (each within the scatter of the next).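

In this assay, the first pair differing in one place gives a 1.3-fold lower number from compound 1 to compound 4 (0.12 log units; within the scatter) and so places compound 1 and compound 4 within the scatter of each other. At this position on the saturated chain carbon bound to an amine nitrogen in a ring, methyl in place of hydrogen, which reads as methyl to ethyl when cut one bond further out, therefore leaves the number without a readable shift. The earlier compounds had no pair differing in only one place and gave no reading for this position, and nothing measured here bears on the reason for the result.

A single step leaves open how far this position stays flat: a propyl chain, a benzyl group or a carboxylic acid on the end of a longer chain could still move the number beyond the scatter. Going by these compounds alone, also open is whether the same change from methyl to ethyl reads the same way on a core other than that of compound 1, since the series holds only this one example of it.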